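A Third Aromatic Group on the Same Core

The source may report more compounds than this note shows. Statements on the series, on what has been measured and on what is new or still open speak of the compounds shown alone.

Compound 2 `Cc1cc(O)c(C(C)C)cc1-c1cc(-c2ccco2)c(C#N)c(=O)[nH]1` gives 26% in a functional assay for inhibition, tested at 20 ug/mL (on this read-out higher numbers stand for a stronger effect at the one concentration tested and lower numbers for a weaker effect), the lowest of the two numbers, while compound 1 `COc1ccc(-c2cc(-c3cc(C(C)C)c(O)cc3C)[nH]c(=O)c2C#N)c(OC)c1` gives 27%, within the scatter of compound 2. Compound 3 `Cc1cc(O)c(C(C)C)cc1-c1cc(-c2ccc(N(C)C)cc2)c(C#N)c(=O)[nH]1` differs from compound 2 at one place: 4-(dimethylamino)phenyl in place of furan-2-yl on an aromatic carbon. Going by the values given here, the one measured step at that place, a number 1 percentage points lower from compound 1 to compound 2 (within the scatter), exchanged one aromatic group for another without moving the read-out beyond the scatter. For compound 3 a step of similar size, or none beyond the scatter, is therefore expected in this assay, namely a number 2 percentage points higher from compound 2 to compound 3 (within the scatter). Compound 3 is expected to give 28%, within 12% to 45%.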

Compound 3, a percentage reported as inhibition, at one concentration (the size of the read-out at that concentration, not a potency): 30%
Compound 3: middle estimate off by 2 percentage points, on the low side; measured number inside the range.
By their numbers in this assay, from the lowest: compounds 2, 1 and 3 (each within the scatter of the next).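

Putting 4-(dimethylamino)phenyl on this aromatic carbon, ortho to a cyano group, gives a number 4 percentage points higher from compound 2 to compound 3 (within the scatter) in this assay and, against 2,4-dimethoxyphenyl, a number 3 percentage points higher from compound 1 to compound 3 (within the scatter) at this position. A five-membered aromatic ring and two substituted six-membered ones therefore read alike here, even with the larger group entering in place of furan-2-yl. No supporting measurement bears on why these numbers stay together.

On these data alone, whether a non-aromatic group here, such as an amine, a carboxylic acid or a longer chain, would read alike remains open. One tested concentration also leaves the potency of these compounds open.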